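The source may hold more compounds than are shown below. What is called first, only, known or untested is meant among the compounds shown, and "the series" means these compounds.

Measured so far in a physicochemical assay for solubility, read by HPLC; on this read-out higher numbers stand for higher solubility and lower numbers for lower solubility:
compound 1, `O=C(CC1CCCCC1)N1CCN(c2nc(=O)c3cc(C(F)(F)F)cc([N+](=O)[O-])c3s2)CC1`, gives 0.12 ug/mL
compound 2, `CC(C)(C)C(=O)N1CCN(c2nc(=O)c3cc(C(F)(F)F)cc([N+](=O)[O-])c3s2)CC1`, gives 5.87 ug/mL
compound 3, `CCC(C)C(=O)N1CCN(c2nc(=O)c3cc(C(F)(F)F)cc([N+](=O)[O-])c3s2)CC1`, gives 104 ug/mL

Compound 2 stands second highest of the three numbers. Its position is fixed by two steps: a 49-fold higher number from compound 1 to compound 2 (1.69 log units; beyond the scatter) and an 18-fold higher number from compound 2 to compound 3 (1.25 log units; beyond the scatter), both beyond the scatter and both changing only the group on the carbonyl carbon. The widest span across the set, an 870-fold higher number from compound 1 to compound 3 (2.94 log units; beyond the scatter), shows how strongly this assay answers to that one position.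

Compound 4, `O=C(c1cccc(F)c1)N1CCN(c2nc(=O)c3cc(C(F)(F)F)cc([N+](=O)[O-])c3s2)CC1`, is not yet measured. Its change from compound 2 is 3-fluorophenyl in place of tert-butyl on a carbonyl carbon. All three measured steps bear on it in that they alter the same group on the carbonyl carbon, and each of them was large. None of them, however, brings in an aromatic ring, so they give the size of the expected step but not its direction with any confidence. The lowest number in the set belongs to compound 1, which carries the largest group at this position, and compound 4 carries more heavy atoms than compound 2, so a move downward is expected, of moderate size: a 2.3-fold lower number from compound 2 to compound 4 (0.37 log units; beyond the scatter). Compound 4 is therefore estimated at 2.5 ug/mL, with a range of 0.3 ug/mL to 25 ug/mL.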

Compound 4, solubility: 0.2 ug/mL
Beside the measured number, compound 4's estimate is 13-fold (1.10 log units) above it, outside the stated range (below it).
By their numbers in this assay, from the lowest: compounds 1 and 4 (each within the scatter of the next); then compound 2; then compound 3.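

In this assay, within the data shown here, 3-fluorophenyl is the first aromatic group at this carbonyl carbon, and the change is large against both groups without a ring, with a 29-fold lower number from compound 2 to compound 4 (1.47 log units; beyond the scatter) and with a 520-fold lower number from compound 3 to compound 4 (2.72 log units; beyond the scatter). Against cyclohexylmethyl the same change gives a 1.7-fold higher number from compound 1 to compound 4 (0.22 log units; within the scatter), so compounds 1 and 4 now share the low end of the series, and among these four compounds the two groups carrying a ring sit apart from the two open branched groups, with none going against that split. No measurement on these compounds accounts for this split, and the data offer no reason for it.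

From the compounds shown here alone, whether the split follows from having a ring at all, from the fluorine, or from the number of heavy atoms stays open, and plain phenyl, a pyridine ring or a longer unbranched chain on the carbonyl carbon would separate these readings. Equally open, going by these compounds, is whether an amine or a carboxylic acid on that carbon, or on the 3-fluorophenyl ring, would lift a ring-bearing compound back towards the level of compound 3.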